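A few compounds are considered here, and "the series" means these few. Any claim that something is new, unique, unknown or untested is made for them only; others in the source may bear on it.

Compound 1 `CC(C)(C)c1nc2ccc(NCc3cccc(C(F)(F)F)c3)cc2n(CCNC(=O)CO)c1=O` — in an assay for inhibition of acyl-CoA desaturase 1 (Rattus norvegicus), using microsomes (a lower number here means a stronger inhibitor, a higher number a weaker inhibitor), compound 1 gives > 3000 nM, which is a limit of the assay rather than a number.
Compound 2 `CC(C)c1nc2ccc(NCc3cccc(C(F)(F)F)c3)cc2n(CCNC(=O)CO)c1=O` — in this assay compound 2 gives 2800 nM.
Compound 3 `Cc1nc2ccc(NCc3cccc(C(F)(F)F)c3)cc2n(CCNC(=O)[C@H](C)O)c1=O` — in this assay compound 3 gives 8000 nM.

Compound 3 stands highest of the two numbers shown; the nearest is compound 2, whose number is lower by a gap beyond the scatter. Compound 4 `Cc1nc2ccc(NCc3cccc(C(F)(F)F)c3)cc2n(CCNC(=O)[C@@H](C)O)c1=O` differs from compound 3 only in configuration: the two compounds have the same atoms and bonds and differ only in configuration as drawn: 1 of 1 stereo elements differ; a stereocentre at a saturated chain carbon is drawn S in compound 3 and R in compound 4. Within the data shown here, the one measured step, an at least 1.0-fold lower number from compound 1 to compound 2 (0.02 log units; that floor lies within the scatter), concerns a change of substituent, not of configuration, so no measured step bears on this change. Nothing shown tells how much a change of configuration alone moves this assay, so a wide range is expected around the unchanged number. Compound 4 is therefore estimated at 8000 nM, within 2500 nM to 25000 nM, with no change at the digits printed from compound 3 to compound 4 (within the scatter) as the expected step.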

Compound 4, half-maximal inhibitory concentration: 3900 nM
The estimate for compound 4 lay 2.1-fold (0.31 log units) above the measured number; the measured number falls inside the stated range.
By their numbers in this assay, from the lowest: compounds 2 and 4 (each within the scatter of the next); then compound 3.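

The earlier compounds shown here differ in a substituent, whereas this pair shows that configuration alone at this saturated chain carbon can move the result: in this assay there is a 2.1-fold lower number from compound 3 to compound 4 (0.31 log units; beyond the scatter), favouring the R form. The step can be traced to this stereocentre alone because nothing else separates the pair: the fact that compounds 3 and 4 differ only in the configuration as drawn.

On these data alone, what an amine or a carboxylic acid in place of the hydroxyl on this chain would give in this assay stays open. So does whether the R form keeps its edge when the shared core carries a larger group than methyl.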